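Trading a Benzyloxycarbonyl Group for an Aminopropyl Chain

This account rests on a few compounds, and the source may have more. Where it says the series, first, only, none or still open, it means among the compounds named here.

For the measured compounds named here, compound 2 `O=C(CN(c1nc(Cl)nc2[nH]cnc12)C1CC1)N[C@@H](CC(=O)OCc1ccccc1)C(=O)OCc1ccccc1` gives 6.68% in a functional assay on the whole organism (Tail, strain ICR) with Mus musculus as the target, in the tail flick test, with a stated time of 150 min, at a dose of 25 umol/kg by the oral route (a lower number here means a weaker effect, a higher number a stronger effect of the compound at the dose given), the lowest of the two numbers measured so far; its nearest neighbour, compound 1 `C[C@@H](O)[C@H](NC(=O)CN(c1nc(Cl)nc2[nH]cnc12)C1CC1)C(=O)OCc1ccccc1`, gives 12.8%, and the step of a number 6.1 percentage points lower from compound 1 to compound 2 (within the scatter) lies within the scatter. Compound 3 `NCCCC[C@H](NC(=O)CN(c1nc(Cl)nc2[nH]cnc12)C1CC1)C(=O)OCc1ccccc1` differs from compound 2 in one place: 3-aminopropyl in place of benzyloxycarbonyl on a saturated chain carbon, two bonds along the chain from an amide-type nitrogen and a carbonyl carbon. Going by the values given here, no measured step bears on this change directly; the only step available, a number 6.1 percentage points lower from compound 1 to compound 2 (within the scatter), concerns a different exchange and stayed within the scatter. It is therefore expected that a number 2.3 percentage points higher from compound 2 to compound 3 (within the scatter) remains within the scatter. Compound 3 is estimated at 9%, with a range from 0% to 25%.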

Compound 3, a percentage reported as activity, at one dose (the size of the read-out at that dose, not a potency): 9.88%
For compound 3 the middle estimate is 0.9 percentage points below the measured one, within the range that was stated.
By their numbers in this assay, from the lowest: compounds 2, 3 and 1 (each within the scatter of the next).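

At the saturated chain carbon, two bonds along the chain from an amide-type nitrogen and a carbonyl carbon, 3-aminopropyl in place of benzyloxycarbonyl gives a number 3.2 percentage points higher from compound 2 to compound 3 (within the scatter) in this assay, and 4-aminobutyl in place of 1-hydroxyethyl gives a number 2.9 percentage points lower from compound 1 to compound 3 (within the scatter). A chain ending in an amine, with no ring, thus stands within the scatter of both the (benzyloxycarbonyl)methyl and the 1-hydroxyethyl compounds. Nothing given here explains this result. On these data alone, whether a carboxylic acid or a guanidine at the end of this chain would give a step beyond the scatter remains open.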